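The source may report more compounds than this note shows. Statements on the series, on what has been measured and on what is new or still open speak of the compounds shown alone.

Measured so far:
compound 1, `COc1cccc(/C=C/C(=O)c2ccc(OCCn3cc(CN4C(=O)/C=C/C(C)(C)C/C=C(\C)CC/C=C/4C)nn3)cc2O)c1`, 1.01 ug/mL
compound 2, `COc1ccccc1/C=C/C(=O)c1ccc(OCCn2cc(CN3C(=O)/C=C/C(C)(C)C/C=C(\C)CC/C=C/3C)nn2)cc1O`, 1.71 ug/mL

Both compounds were tested in a functional assay on HepG2 cells (Homo sapiens) for antiproliferative activity; a higher number here means a weaker inhibitor, a lower number a stronger inhibitor. Compound 2 holds the highest of the two numbers, but the step of a 1.7-fold higher number from compound 1 to compound 2 (0.23 log units; within the scatter) lies within the scatter, so compound 1 and compound 2 cannot be ranked against each other. Compound 3, `C/C1=C\CC(C)(C)/C=C/C(=O)N(Cc2cn(CCOc3ccc(C(=O)/C=C/c4ccc(C)cc4)c(O)c3)nn2)/C(C)=C/CC1`, differs from compound 2 by 4-methylphenyl in place of 2-methoxyphenyl on a double-bonded chain carbon bound to a double-bonded chain carbon. Among the measured compounds shown here, the only measured step, from compound 1 to compound 2, exchanged 3-methoxyphenyl for 2-methoxyphenyl and stayed within the scatter; no measured step exchanges a methoxyphenyl for a methylphenyl, so there is nothing in these numbers that points to a shift beyond the scatter in this assay. Compound 3 is therefore expected to land close to compound 2, with an expected step of a 1.1-fold lower number from compound 2 to compound 3 (0.03 log units; within the scatter). The estimate for compound 3 in this assay is 1.6 ug/mL, within a range of 0.6 ug/mL to 4.5 ug/mL.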

Compound 3, half-maximal inhibitory concentration: 0.87 ug/mL
The estimate for compound 3 lay 1.8-fold (0.26 log units) above the measured number, and the stated range covers the measured number.
By their numbers in this assay, from the lowest: compounds 3, 1 and 2 (each within the scatter of the next).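

In this assay, among the compounds shown here, the 4-methylphenyl group brings a substituent without oxygen to the position on a double-bonded chain carbon bound to a double-bonded chain carbon, where the earlier compounds both carried a methoxyphenyl. Its steps read a 2.0-fold lower number from compound 2 to compound 3 (0.29 log units; within the scatter) and a 1.2-fold lower number from compound 1 to compound 3 (0.06 log units; within the scatter), so replacing either methoxyphenyl with this methylphenyl does not separate the compounds, and all three remain unranked at this position. Nothing at hand bears on why this exchange reads as it does.

The compounds shown leave open whether a phenyl ring carrying an amine or a carboxylic acid at this position would step beyond the scatter. They also leave open whether 2-methylphenyl or 3-methylphenyl would read like 4-methylphenyl.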